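This account rests on a few compounds, and the source may have more. Where it says the series, first, only, none or still open, it means among the compounds named here.

Compound 1 `CCCCOC(=O)CNC(=O)[C@H](CSc1ccc([N+](=O)[O-])cc1[N+](=O)[O-])NC(=O)CC[C@H](NC(=O)CC(C)(C)C)C(=O)OCCCC` is tested in a toxicity assay on KB cells (Homo sapiens) for cytotoxicity, read by fluorescence, with a stated time of 3 days (on this read-out lower numbers stand for an effect already at smaller amounts and higher numbers for an effect only at larger amounts of compound), where compound 1 gives 250 uM. Among the numbers at hand this is the highest; compound 3 `CCCCOC(=O)CNC(=O)[C@H](CSc1ccc([N+](=O)[O-])cc1[N+](=O)[O-])NC(=O)CC[C@H](NC(=O)CCc1c[nH]c2ccccc12)C(=O)OCCCC` gives 26 uM, and the step of a 9.6-fold lower number from compound 1 to compound 3 (0.98 log units; beyond the scatter) puts (1H-indol-3-yl)methyl in place of tert-butyl. Compound 2 `CCCCOC(=O)CNC(=O)[C@H](CSc1ccc([N+](=O)[O-])cc1[N+](=O)[O-])NC(=O)CC[C@H](NC(=O)COc1ccccc1)C(=O)OCCCC` gives only a limit, > 300 uM. The step of an at least 1.2-fold higher number from compound 1 to compound 2 (0.07 log units; that floor lies within the scatter) puts phenoxy in place of tert-butyl. Compound 4 `CCCCOC(=O)CNC(=O)[C@H](CSc1ccc([N+](=O)[O-])cc1[N+](=O)[O-])NC(=O)CC[C@H](NC(=O)OCc1ccccc1)C(=O)OCCCC` differs from compound 1 by benzyloxy in place of neopentyl on a carbonyl carbon. Benzyloxy, like phenoxy, brings one six-membered aromatic ring of carbon only together with one oxygen, so the step to compound 2 is the closer guide, and no change beyond the scatter is expected. Compound 4 is therefore expected to give 250 uM, between 120 uM and 500 uM, a step of no change at the digits printed from compound 1 to compound 4 (within the scatter).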

Compound 4, concentration for half-maximal effect: 95.2 uM
Estimate against measurement, compound 4: 2.6-fold (0.42 log units) above; the measured number lies below the stated range.
By their numbers in this assay, from the lowest: compound 3; then compound 4; then compound 1. At a limit, above all of these: compound 2.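

In this assay, benzyloxy in place of neopentyl gives a 2.6-fold lower number from compound 1 to compound 4 (0.42 log units; beyond the scatter), so a ring joined through an oxygen need not leave the number high at this carbonyl carbon, as the phenoxy result alone might have suggested. Benzyloxy still does not match the indole-bearing chain, with a 3.7-fold higher number from compound 3 to compound 4 (0.56 log units; beyond the scatter). Moving from phenoxymethyl to benzyloxy gives an at least 3.1-fold lower number from compound 2 to compound 4 (0.49 log units; beyond the scatter), but this step starts from a limit and not a number: the limit of > 300 uM in this assay, at which 1 of the 4 values shown sits.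

On these data alone, how an amine, a carboxylic acid or a longer chain without a ring would read on this carbonyl carbon remains open. So does whether a plain phenyl ring joined without oxygen would behave like benzyloxy.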